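The source may hold more compounds than are shown below. What is called first, only, known or untested is meant among the compounds shown, and "the series" means these compounds.

Measured so far: compound 1 `O=C(NCc1ccc(S(=O)(=O)N2CCCCC2)cc1)c1cc2ccncc2[nH]1` gives 1000 nM in an assay for inhibition of Nicotinamide phosphoribosyltransferase (Homo sapiens), read by mass spectrometry, with stated times of 15 min and 30 min; a lower number here means a stronger inhibitor, a higher number a weaker inhibitor; compound 2 `O=C(NCc1ccc(S(=O)(=O)N2CCCCC2)cc1)c1cnc2nccn2c1` gives 3 nM in the same assay.

Compound 2 gives the lowest of the two numbers seen; the nearest measured compound is compound 1, and the step of a 330-fold lower number from compound 1 to compound 2 (2.52 log units; beyond the scatter) sets compound 2 well apart from it. The unmeasured compound 3 `O=C(NCc1ccc(S(=O)(=O)N2CCCCC2)cc1)c1cc2cccnc2s1` keeps the amide and the sulfonyl-bearing part of compound 2 and changes only the aromatic group on the carbonyl carbon: a group of 9 heavy atoms (7 carbon, 1 nitrogen, 1 sulfur; one five-membered aromatic ring with 1 hetero atom, one six-membered aromatic ring with 1 hetero atom) in place of a group of 9 heavy atoms (6 carbon, 3 nitrogen; one five-membered aromatic ring with 2 hetero atoms, one six-membered aromatic ring with 2 hetero atoms), on a carbonyl carbon.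

Among the compounds with values here, only one measured step bears on this change, the exchange of fused aromatic groups on the carbonyl carbon between compound 1 and compound 2, which was large. It shows that this assay responds strongly to the choice of fused ring system at this place, with one acceptor-richer system giving the much lower number. Within the data shown here, compound 3 moves back toward a system with fewer heteroatoms and fewer acceptors, though not to the one in compound 1, so a step upward beyond the scatter is expected: a 33-fold higher number from compound 2 to compound 3 (1.52 log units; beyond the scatter). Compound 3 is estimated to give 100 nM, within a range from 15 nM to 800 nM.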

Compound 3, half-maximal inhibitory concentration: 8 nM
Compound 3: middle estimate off by 13-fold (1.10 log units), on the high side, outside the stated range (below it).
By their numbers in this assay, from the lowest: compound 2; then compound 3; then compound 1.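

With 2 hydrogen-bond acceptors in the entering group against 3 in the group it replaces, the exchange on the carbonyl carbon cost little in this assay: a 2.7-fold higher number from compound 2 to compound 3 (0.43 log units; beyond the scatter), a modest step though beyond the scatter. The earlier pair had suggested that this place tolerates little change, but a low number here does not depend on the group of compound 2, with its five-membered aromatic ring with 2 hetero atoms and six-membered aromatic ring with 2 hetero atoms. The sharper contrast lies elsewhere, a 130-fold lower number from compound 1 to compound 3 (2.10 log units; beyond the scatter), a large step between two groups that each have one five-membered aromatic ring with 1 hetero atom and one six-membered aromatic ring with 1 hetero atom, so these ring counts alone do not set the number at this place. No measurement at hand accounts for the size of either step.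

The compounds shown leave open which feature of the fused groups separates compound 1 from compound 2 and compound 3. They also leave open whether anything other than a fused aromatic group, such as a longer chain, an amine or a carboxylic acid, could stand on this carbonyl carbon and keep the number low.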